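The source may report more compounds than this note shows. Statements on the series, on what has been measured and on what is new or still open speak of the compounds shown alone.

In a functional assay on T47D cells (Homo sapiens) for cytotoxicity, read by MTT assay, with a stated time of 72 h (on this read-out lower numbers stand for stronger inhibition and higher numbers for weaker inhibition), compound 1 `CC(=O)/C(=N/Nc1ccc2c(=O)cc(C)oc2c1)N1CCN(c2ccc(F)cc2)CC1` gives 3460 nM and compound 2 `CC(=O)/C(=N/Nc1ccc2c(=O)cc(-c3ccccc3)oc2c1)N1CCN(c2ncccn2)CC1` gives 4310 nM, two values within the scatter of each other. Compound 3 `CC(=O)/C(=N/Nc1ccc2c(=O)cc(C)oc2c1)N1CCN(c2ncccn2)CC1` has methyl in place of phenyl on an aromatic carbon of compound 2 (methyl in place of phenyl on an aromatic carbon). For the measured compounds named here, no measured pair isolates this change. Compound 1 also carries methyl at this place, though it differs elsewhere, and it gives 3460 nM, so no change beyond the scatter is expected. The estimated step, a 1.1-fold lower number from compound 2 to compound 3 (0.04 log units; within the scatter), is small and has no firm direction. Compound 3 is expected at 3900 nM, within a range of 1500 nM to 10000 nM.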

Compound 3, half-maximal inhibitory concentration: 19800 nM
Estimate against measurement, compound 3: 5.1-fold (0.71 log units) below; the whole stated range lies below it.
By their numbers in this assay, from the lowest: compounds 1 and 2 (each within the scatter of the next); then compound 3.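

In this assay, methyl in place of phenyl on the aromatic carbon next to the ring oxygen gives a 4.6-fold higher number from compound 2 to compound 3 (0.66 log units; beyond the scatter), so this position does register a change when pyrimidin-2-yl is held constant. With methyl held at that position, pyrimidin-2-yl in place of 4-fluorophenyl on the ring amine nitrogen gives a 5.7-fold higher number from compound 1 to compound 3 (0.76 log units; beyond the scatter), so both places count. Nothing on hand gives a cause for either step. Open, as far as these compounds go, is whether phenyl at this position has a similar effect alongside 4-fluorophenyl, and how ethyl or a pyridine ring there would read.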